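Swapping the Benzyl Substituent: Fluorine to Nitrile

The compounds below may be only part of what the source reports. "The series", "measured", "known", "first", "only" and "open" are said of these compounds alone.

Among the measured compounds shown here, compound 2 `O=c1ccoc2cc(OCc3cn(Cc4ccccc4F)nn3)ccc12` is one of two compounds tested in a functional assay on QGY7701 cells (Homo sapiens) for cytotoxicity, read by MTT assay, with a stated time of 48 h (on this read-out higher numbers stand for weaker inhibition and lower numbers for stronger inhibition), and in this assay compound 2 gives 36900 nM, the only actual number among the two. Compound 1 `O=c1ccoc2cc(OCc3cn(Cc4cccc(F)c4)nn3)ccc12` gives only a limit of the assay, > 100000 nM, not a number. The change leading to compound 3 `N#Cc1cccc(Cn2cc(COc3ccc4c(=O)ccoc4c3)nn2)c1` is 3-cyanophenyl in place of 2-fluorophenyl on a saturated chain carbon bound to an aromatic nitrogen. For the measured compounds named here, one measured step bears on it: an at least 2.7-fold lower number from compound 1 to compound 2 (0.43 log units; beyond the scatter), a 2-fluorobenzyl replacing a 3-fluorobenzyl, whose full size stays unknown because of the limit of > 100000 nM in this assay, at which 1 of the 2 values shown sits. Going by the values given here, compound 3 goes back to a 3-substituted benzyl and, in addition, exchanges fluorine for a nitrile, an exchange no measured pair covers. A weaker result is therefore expected, roughly a 2.2-fold higher number from compound 2 to compound 3 (0.34 log units; beyond the scatter), with a real chance that this assay reports only a limit. Compound 3 is estimated at 80000 nM, with a range of 30000 nM to 250000 nM.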

Compound 3, half-maximal inhibitory concentration: 24400 nM
Compound 3: the middle estimate sits 3.3-fold (0.52 log units) above what was measured; the whole stated range lies above it.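

Of the two groups on a saturated chain carbon bound to an aromatic nitrogen, 3-cyanophenyl and 2-fluorophenyl cannot be told apart in this assay: the change gives a 1.5-fold lower number from compound 2 to compound 3 (0.18 log units; within the scatter). Exchanging only fluoro for cyano on an aromatic carbon gives an at least 4.0-fold lower number from compound 1 to compound 3 (0.61 log units; beyond the scatter), so the identity of the group counts here, and not only where it sits on the benzyl ring. The full size of that step stays unknown because one end of it is not a number: the limit of > 100000 nM in this assay, at which 1 of the 3 values shown sits.

The compounds shown leave open how a benzyl carrying an amine or a carboxylic acid in place of the nitrile would read in this assay. They also hold no measurement that could explain why the nitrile and fluorine differ.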